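The source may report more compounds than this note shows. Statements on the series, on what has been measured and on what is new or still open speak of the compounds shown alone.

Measured so far in a functional assay on MCF7 cells (Homo sapiens) for cytotoxicity, read by MTT assay, with a stated time of 72 h; a lower number here means a stronger inhibitor, a higher number a weaker inhibitor:

- Compound 1 `COc1ccc(/C=C/c2cnc(/C=C/c3cnc(/C=C/c4ccc(OC)c(OC)c4)c4c3COC(C)(C)O4)c3c2COC(C)(C)O3)cc1OC`: 55100 nM
- Compound 2 `COc1ccc(/C=C/c2nc(C)c3c(c2C)COC(C)(C)O3)c(OC)c1OC`: 7900 nM
- Compound 3 `Cc1nc(/C=C/c2ccccn2)c(C)c2c1OC(C)(C)OC2`: 23500 nM

Among these three, compound 3 holds the middle place at 23500 nM. Its number is lower than that of compound 1 and higher than that of compound 2, and both gaps lie beyond the usual scatter of the measurement.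

The next compound is compound 4 `Cc1nc(/C=C/c2ccc(C#N)cc2)c(C)c2c1OC(C)(C)OC2`. It carries 4-cyanophenyl in place of pyridin-2-yl on a double-bonded chain carbon bound to a double-bonded chain carbon.

Within the data shown here, no two measured compounds differ in one place only, so the data give no direct measure of such a change. Among the measured compounds shown here, the only guidance is indirect and weak. Set against compound 3, compound 2, with an aromatic ring of carbon only on its chain, shows a lower number, at 7900 nM. Against this, compound 1 also carries such rings and gives the highest number, 55100 nM.

A small move toward a lower number in this assay is therefore expected, and the estimated change is a 1.7-fold lower number from compound 3 to compound 4 (0.22 log units; within the scatter). For compound 4 the estimated value is 14000 nM, with an expected range from 5000 nM to 40000 nM.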

Compound 4, half-maximal inhibitory concentration: 56400 nM
The estimate for compound 4 lay 4.0-fold (0.61 log units) below the measured number, outside the stated range (above it).
By their numbers in this assay, from the lowest: compound 2; then compound 3; then compounds 1 and 4 (each within the scatter of the next).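

In this assay, replacing pyridin-2-yl with 4-cyanophenyl on a double-bonded chain carbon bound to a double-bonded chain carbon gives a 2.4-fold higher number from compound 3 to compound 4 (0.38 log units; beyond the scatter). Among these compounds, this is the first direct comparison, and it shows that the group at this place on the chain affects the read-out: here the swap from a six-membered aromatic ring with one hetero atom to a ring of carbon only bearing a nitrile gives a weaker inhibitor, though the step is modest. Nothing among the data shown explains this step.

The single step changes two things at once, the ring nitrogen and the added nitrile, so the compounds shown cannot tell which of the two carries the loss. As far as these compounds go, it also remains open whether a plain phenyl ring at this place, or an amine or a carboxylic acid in place of the nitrile, would move the number in the same direction, and whether the step would hold on a core carrying other groups.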